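This account rests on a few compounds, and the source may have more. Where it says the series, first, only, none or still open, it means among the compounds named here.

Compound 1 `Cc1ccc(NC2=CC(=O)c3c(nc4n3[C@H]3OC[C@@H](O)[C@H]3OC4)C2=O)cc1`: > 4000 nM (a limit)
Compound 2 `CCc1ccc(NC2=CC(=O)c3nc4n(c3C2=O)[C@H]2OC[C@@H](O)[C@H]2OC4)cc1`: 960 nM

In a functional assay on MCF7 cells (Homo sapiens) for inhibition, read by sulforhodamine B assay (a lower number here means a stronger inhibitor, a higher number a weaker inhibitor), compound 1 stands only at a limit, > 4000 nM, and has no exact number. Compound 2 gives a measured 960 nM. Compound 3 `O=C1C(NC2CC2)=CC(=O)c2c1nc1n2[C@H]2OC[C@@H](O)[C@H]2OC1` keeps the core of compound 1 but carries cyclopropyl in place of 4-methylphenyl on an amine nitrogen. Resting on what is known of compound 1, (the limit of > 4000 nM in this assay, at which 1 of the 2 values shown sits), the step expected in this assay is none beyond the scatter: a number no higher from compound 1 to compound 3 (the limit leaves the size open). Compound 3 is estimated at 4000 nM, with an expected range of 1500 nM to 12000 nM.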

Compound 3, half-maximal inhibitory concentration: > 16000 nM
Compound 3 was reported as a limit (the forecaster's own chance of this, stated with the estimate: 45%); middle value at least 4.0-fold (0.60 log units) from the limit.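

No step can be read between compound 1 and compound 3, since both stand only as limits. The compounds shown leave open whether cyclopropyl in place of 4-methylphenyl on an amine nitrogen changes inhibition at all, and in which direction.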